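This account rests on a few compounds, and the source may have more. Where it says the series, first, only, none or still open, it means among the compounds named here.

Compound 3 `COc1ccc(-c2cnc(NC(=O)c3ccc(F)cc3)n2C)cc1` carries the unsubstituted amide on the shared core. In a toxicity assay on THP-1 cells (Homo sapiens) for inhibition (on this read-out lower numbers stand for higher toxicity in this test and higher numbers for lower toxicity in this test), compound 3 gives >= 50000 nM, which is a limit of the assay and not a number. Compound 1 `CCCCn1c(-c2ccc(OC)cc2)cnc1NC(=O)c1ccc(F)cc1` gives > 100000 nM in this assay, again a limit rather than a number. Among the compounds with values here, compound 2 `Cn1c(-c2ccc(Cl)cc2)cnc1NC(=O)c1ccc(F)cc1` gives 37000 nM in this assay, the one plain number of the three. Within the data shown here, the step of an at least 1.3-fold higher number from compound 2 to compound 3 (0.13 log units; that floor lies within the scatter) is the only readable one, and the step that the two limits leave unreadable from compound 1 to compound 3 cannot be sized, so the change on the aromatic nitrogen has no measured precedent here. Compound 4 `COc1ccc(-c2cnc(NC(=O)c3ccc(F)cc3)[nH]2)cc1` differs from compound 3 by hydrogen in place of methyl on an aromatic nitrogen. No step beyond the scatter is expected in this assay. For compound 4 the estimate is 50000 nM, range 20000 nM to 150000 nM, an expected step of a number no higher from compound 3 to compound 4 (the limit leaves the size open).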

Compound 4, half-maximal cytotoxic concentration: > 100000 nM
Compound 4 was reported as a limit; the forecaster's own chance of this, stated with the estimate: 65%; at least 2.0-fold (0.30 log units) between middle value and limit.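

In this assay compound 4 gives > 100000 nM, a limit and not a number. The steps to compound 4 from compound 3 and from compound 1 cannot be read; all three values are limits. The compounds shown leave open the size of any change in this assay with hydrogen in place of methyl on the aromatic nitrogen.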